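Cyclopentyl Amide Replaces Pyridyl Amide on Piperazine Benzimidazole

The source may report more compounds than this note shows. Statements on the series, on what has been measured and on what is new or still open speak of the compounds shown alone.

Measured compounds:
compound 1 `CC(C)=CCn1c(CN2CCN(C(=O)C3CC3)CC2)nc2ccccc21`: 74.3%
compound 2 `Cc1cccc(Cn2c(CN3CCN(C(=O)c4ccc([N+](=O)[O-])cc4)CC3)nc3ccccc32)c1`: 24.3%
compound 3 `Cc1cccc(Cn2c(CN3CCN(C(=O)c4cccnc4)CC3)nc3ccccc32)c1`: 24.5%

In an assay on isolated protein for inhibition of aldehyde dehydrogenase 1A1 (Homo sapiens), read by spectrophotometry, tested at 10 uM (a higher number here means more inhibition at the concentration tested (going by the name of the read-out), a lower number less inhibition), compound 3 gives 24.5%, the second highest of the three numbers; compound 2 lies within the scatter of it, while compound 1 gives a far higher reading. Compound 4 `Cc1cccc(Cn2c(CN3CCN(C(=O)C4CCCC4)CC3)nc3ccccc32)c1` differs from compound 3 by cyclopentyl in place of pyridin-3-yl on a carbonyl carbon. Going by the values given here, the one step that touches the carbonyl substituent, a number 0.2 percentage points higher from compound 2 to compound 3 (within the scatter), changed nothing beyond the scatter. Compound 1 carries a small non-aromatic carbon ring on the carbonyl and reads high, but it also differs from compound 3 elsewhere, so its value cannot be attributed to the acyl group alone. Compound 4 is therefore expected to show a number 15.5 percentage points higher from compound 3 to compound 4 (beyond the scatter), with wide uncertainty. The estimate for compound 4 is 40%, with a range from 15% to 70%.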

Compound 4, a percentage reported as inhibition, at one concentration (the size of the read-out at that concentration, not a potency): 67.5%
Compound 4: the middle estimate sits 27.5 percentage points below what was measured; low and high end bracket the measured number.
By their numbers in this assay, from the lowest: compounds 2 and 3 (each within the scatter of the next); then compounds 4 and 1 (each within the scatter of the next).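

In this assay the carbonyl substituent turns out to matter: a number 43 percentage points higher from compound 3 to compound 4 (beyond the scatter) and a number 43.2 percentage points higher from compound 2 to compound 4 (beyond the scatter) on the shared core. The exchange of one aromatic group for the other had moved nothing beyond the scatter, whereas cyclopentyl in place of either one gives a large step. Nothing measured here accounts for that step.

The compounds shown leave open whether the step belongs to cyclopentyl itself or extends to other non-aromatic groups. A cyclohexyl group, an isobutyl chain or a piperidin-4-yl ring with its amine on the same carbonyl carbon might read like either compound 3 or compound 4.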